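This account rests on a few compounds, and the source may have more. Where it says the series, first, only, none or still open, it means among the compounds named here.

Measured compounds:
compound 1 `CC(=O)N1CCN(C(=O)N2Cc3c(NC(=O)c4ccc(F)cc4)n[nH]c3C2(C)C)CC1`: > 10000 nM
compound 2 `CC(C)(C)C(=O)N1Cc2c(NC(=O)c3ccc(F)cc3)n[nH]c2C1(C)C`: 270 nM

Of the compounds shown here, two have been tested in a functional assay on A2780 cells (Homo sapiens) for antiproliferative activity, read by fluorescence, with a stated time of 72 h; a lower number here means a stronger inhibitor, a higher number a weaker inhibitor. For compound 1 the result is only a limit of the assay, > 10000 nM, not a number. Among the compounds with values here, compound 2 gives 270 nM, the only actual number in hand, so it stands alone among the results. Within the data shown here, the single measured step, an at least 37-fold lower number from compound 1 to compound 2 (1.56 log units; beyond the scatter), is the only comparison available, and it runs toward stronger inhibition. Compound 3 `CN1CCN(C(=O)N2Cc3c(NC(=O)c4ccc(F)cc4)n[nH]c3C2(C)C)CC1` has not yet been measured. Its change from compound 2: 4-methylpiperazin-1-yl in place of tert-butyl on a carbonyl carbon. This change largely undoes the measured step, since compound 3 carries a piperazine ring on the same carbonyl carbon as compound 1 does. Compound 1 sits at the limit (the limit of > 10000 nM in this assay, at which 1 of the 2 values shown sits). The step from compound 2 to compound 3 is therefore expected to run back toward weaker inhibition, with a size comparable to an at least 37-fold lower number from compound 1 to compound 2 (1.56 log units; beyond the scatter) taken in reverse. The expected step is a 30-fold higher number from compound 2 to compound 3 (1.47 log units; beyond the scatter). Compound 3 is estimated at 8000 nM, within 2000 nM to 30000 nM, with a real chance that the assay again reports only a limit.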

Compound 3, half-maximal inhibitory concentration: 180 nM
Estimate against measurement, compound 3: 44-fold (1.65 log units) above; measured number outside the range, below it.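

In this assay, a piperazine ring on this carbonyl carbon does not by itself go with the loss of activity: putting 4-methylpiperazin-1-yl in place of tert-butyl gives a 1.5-fold lower number from compound 2 to compound 3 (0.18 log units; within the scatter), so these two groups cannot be told apart at this position. The large change instead follows the group on the amine nitrogen in the ring, where methyl in place of acetyl gives an at least 55-fold lower number from compound 1 to compound 3 (1.74 log units; beyond the scatter), a difference that the first two compounds alone could not reveal. The result for compound 1 is a limit of the assay, not a number: the limit of > 10000 nM in this assay, at which 1 of the 3 values shown sits.

The compounds shown leave open whether weak inhibition is specific to the acetyl group, or whether other groups on that ring nitrogen, such as a plain hydrogen, an ethyl group or a longer chain ending in a carboxylic acid, would behave like acetyl or like methyl. They also leave open how far the carbonyl carbon tolerates other groups, for example a morpholine ring or a simple primary amine.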